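This account rests on a few compounds, and the source may have more. Where it says the series, first, only, none or still open, it means among the compounds named here.

All four compounds share one core. Compound 1 `C=CC[C@H]1C[C@]2([C@@H](C)Cc3ccc(OC)c(C(N)=O)c3)OCOC2=CC1=O` carries a carbamoyl group on its aromatic ring, and in a functional assay on NCI-H460 cells (Homo sapiens) for antiproliferative activity, with a stated time of 72 h (a higher number here means a weaker inhibitor, a lower number a stronger inhibitor), compound 1 gives 66 nM. Compound 2 `C=CC[C@H]1C[C@]2([C@@H](C)Cc3ccc(OC)c(C#N)c3)OCOC2=CC1=O` has a cyano group in place of that carbamoyl, and in this assay compound 2 gives 340 nM; the change brought a 5.2-fold higher number from compound 1 to compound 2 (0.71 log units; beyond the scatter). Compound 3 `C=CC[C@H]1C[C@]2([C@@H](C)Cc3cc(C#N)c(OC)cc3F)OCOC2=CC1=O` adds a fluoro to the ring of compound 2, and in this assay compound 3 gives 150 nM, after a step of a 2.3-fold lower number from compound 2 to compound 3 (0.36 log units; beyond the scatter). Among the three measured numbers compound 3 stands second highest, weaker than compound 1 and stronger than compound 2.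

Compound 4 `C=CC[C@H]1C[C@]2([C@@H](C)Cc3cc(F)c(OC)cc3F)OCOC2=CC1=O` follows with this change: fluoro in place of cyano on an aromatic carbon. Going by the values given here, no measured step swaps cyano for fluoro directly. Among the compounds with values here, two steps bear on it: swapping the group on this carbon gave a 5.2-fold higher number from compound 1 to compound 2 (0.71 log units; beyond the scatter), while a fluoro entering the ring gave a 2.3-fold lower number from compound 2 to compound 3 (0.36 log units; beyond the scatter). Because a 5.2-fold higher number from compound 1 to compound 2 (0.71 log units; beyond the scatter) came from replacing a larger polar group with a smaller one, a further loss of the cyano is expected to raise the number again, by a modest amount. Compound 4 is therefore expected to give about 400 nM in this assay, most likely between 130 nM and 1300 nM. That estimate means a step of a 2.7-fold higher number from compound 3 to compound 4 (0.43 log units; beyond the scatter) is expected.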

Compound 4, half-maximal inhibitory concentration: 59 nM
Beside the measured number, compound 4's estimate is 6.8-fold (0.83 log units) above it; the whole stated range lies above it.
By their numbers in this assay, from the lowest: compounds 4 and 1 (each within the scatter of the next); then compound 3; then compound 2.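

At this ring carbon, ortho to a methoxy group and para to a fluoro group, the cyano group is not required for activity: in this assay, fluoro in its place gave a 2.5-fold lower number from compound 3 to compound 4 (0.41 log units; beyond the scatter). The earlier swap at this carbon, cyano in place of carbamoyl, gave a 5.2-fold higher number from compound 1 to compound 2 (0.71 log units; beyond the scatter), whereas this second change to a group with fewer heavy atoms moved the number the opposite way, so heavy-atom count alone does not track the number across these steps. No measurement available here explains this reversal.

Going by these compounds, how a chlorine, a methyl group or an amine would behave at this carbon remains open. So does whether the carbamoyl group would give a lower number than fluoro when the ring also carries the second fluoro group.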